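A trifluoromethoxy swap at the assay limit

The compounds below may be only part of what the source reports. "The series", "measured", "known", "first", "only" and "open" are said of these compounds alone.

Measured so far in an ADME assay on HS27 cells (Homo sapiens) for antiproliferative activity, read by sulforhodamine B assay, with a stated time of 48 h; a higher number here means a weaker inhibitor, a lower number a stronger inhibitor
Compound 1 `O=C(O)c1cc2ccc(-c3ccc(Cl)cc3)cc2n1O` gives > 100000 nM
Compound 2 `O=C(O)c1cc2ccc(-c3ccc(Cl)cc3Cl)cc2n1O` gives > 100000 nM
Compound 3 `O=C(O)c1cc2ccc(-c3ccc4ccccc4c3)cc2n1O` gives > 100000 nM

Each of these three entries is a limit, not a number. Compound 1 has only the limit of > 100000 nM in this assay, at which 3 of the 3 values shown sit, and so no exact rank among the three. Compound 4 `O=C(O)c1cc2ccc(-c3ccc(OC(F)(F)F)cc3)cc2n1O` differs from compound 1 by trifluoromethoxy in place of chloro on an aromatic carbon and carries trifluoromethoxy in place of chloro on an aromatic carbon. For the measured compounds named here, the only measured step that bears on this is a step that the two limits leave unreadable from compound 1 to compound 2 and it offers no size to build on. Compound 1 gives > 100000 nM as its limit, so compound 4 is expected to report a limit in this assay as well. The estimated change is a number no higher from compound 1 to compound 4 (the limit leaves the size open) and no direction can be expected from these data. For compound 4 the estimate is 100000 nM with an expected range from 40000 nM to 200000 nM if a number is reported at all.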

Compound 4, half-maximal inhibitory concentration: > 100000 nM
Compound 4: no number, only a limit (the forecaster's own chance of this, stated with the estimate: 85%); the middle value lies on the limit itself.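

Compound 4, like compound 1, gives only a limit and not a number in this assay, so the step between them cannot be read. Whether either compound has any measurable activity in this assay stays open, and the compounds shown cannot be ranked, because all share one reading: the limit of > 100000 nM in this assay, at which 4 of the 4 values shown sit.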